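Cytotoxicity limit and the hydroxy to methylamino swap

This account rests on a few compounds, and the source may have more. Where it says the series, first, only, none or still open, it means among the compounds named here.

Values in an ADME assay on CEMx174 cells (Homo sapiens) for cytotoxicity (on this read-out higher numbers stand for lower toxicity in this test and lower numbers for higher toxicity in this test), are as follows
Compound 1 `CC1=C(C(=O)OCC2CCCCC2)C(c2cccc(O)c2)N(C)C(=O)N1` gives > 10000 nM as a limit of the assay.
Compound 2 `CCC1=C(C(=O)OCC2CCCCC2)C(c2ccc(O)cc2)NC(=O)N1` gives > 10000 nM as a limit of the assay.

Going by the values given here, compound 2 therefore has no numerical value, only a limit, and no measured step is available for comparison. Among the compounds with values here, the sole evidence in this assay is the limit of > 10000 nM in this assay, at which 2 of the 2 values shown sit, and covers compound 1 and compound 2 alike. Compound 3 `CCC1=C(C(=O)OCC2CCCCC2)C(c2ccc(NC)cc2)NC(=O)N1` carries methylamino in place of hydroxy on an aromatic carbon, para to a large group, with methylamino in place of hydroxy on an aromatic carbon as the counted difference. The expected size of a number no higher from compound 2 to compound 3 (the limit leaves the size open) is none beyond the scatter, with no direction anticipated. In this assay compound 3 is estimated at 10000 nM within an expected range from 4000 nM to 25000 nM. A limit rather than a number is expected again for compound 3.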

Compound 3, half-maximal cytotoxic concentration: > 10000 nM
Compound 3: no number, only a limit; the forecaster's own chance of this, stated with the estimate: 70%; the middle value lies on the limit itself.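

Compound 2 and compound 3 both give only a limit of the assay, so no step can be read between them. The compounds shown leave open whether methylamino in place of hydroxy alters cytotoxicity at all, and what actual numbers these compounds would give.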